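Methoxy for ethyl on the nitrogen-containing ring

A few compounds are considered here, and "the series" means these few. Any claim that something is new, unique, unknown or untested is made for them only; others in the source may bear on it.

Measured compounds in a functional assay on the whole organism with Rattus norvegicus as the target, read by paw edema, with a stated time of 3 h, at a dose of 100 mg/kg by the oral route; a higher number here means more inhibition at the dose given (going by the name of the read-out), a lower number less inhibition:
compound 1 `Cc1ccc2[nH]c(-c3cccc(C)n3)nc2c1` gives 42%
compound 2 `CCc1cccc(-c2nc3cc(C)ccc3[nH]2)n1` gives 10%
compound 3 `CCc1cccc(-c2nc3cc(OC)ccc3[nH]2)n1` gives 52%

Compound 2 stands lowest of the three numbers in this assay. Its nearest neighbour is compound 1, and the step from compound 1 to compound 2 reads a number 32 percentage points lower from compound 1 to compound 2 (beyond the scatter). The furthest is compound 3, reached by a number 42 percentage points higher from compound 2 to compound 3 (beyond the scatter).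

The next compound, compound 4 `COc1cccc(-c2nc3cc(C)ccc3[nH]2)n1`, is not yet measured. It differs from compound 2 as follows: methoxy in place of ethyl on an aromatic carbon

For the measured compounds named here, two measured steps bear on this change, though neither matches it. Going from compound 1 to compound 2 the ethyl group entered in place of methyl on the saturated chain carbon, and the number fell by a large margin beyond the scatter. Going from compound 2 to compound 3 methoxy entered in place of methyl, on the other ring, and the number rose by a large margin beyond the scatter. Removing ethyl has so far gone with a higher number, and bringing in methoxy has gone with a higher number, so a rise beyond the scatter is expected in this assay, of the order of a number 30 percentage points higher from compound 2 to compound 4 (beyond the scatter). Compound 4 is therefore estimated at 40%, with a range from 20% to 62%.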

Compound 4, a percentage reported as inhibition, in the whole organism at one dose (the size of the read-out at that dose, not a potency): 32%
Compound 4: the middle estimate sits 8 percentage points above what was measured, and the stated range covers the measured number.
By their numbers in this assay, from the lowest: compound 2; then compounds 4, 1 and 3 (each within the scatter of the next, the first and the last beyond it).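

On the six-membered aromatic ring with 1 nitrogen, the carbon next to the ring nitrogen now carries three different groups across compounds 1, 2 and 4, and in this assay replacing ethyl there with methoxy gives a number 22 percentage points higher from compound 2 to compound 4 (beyond the scatter). Methoxy and methyl at this carbon cannot be told apart, with a number 10 percentage points lower from compound 1 to compound 4 (within the scatter), so among these three groups only ethyl stands apart, its number lying beyond the scatter from both of the others. The replacement of methyl by methoxy also does not read the same in the two places where it has been seen, the carbon next to the ring nitrogen and the other ring: the same change on two cores in this assay, a number 42 percentage points higher (beyond the scatter) from compound 2 to compound 3 and a number 10 percentage points lower (within the scatter) from compound 1 to compound 4, 52 percentage points apart, beyond the scatter of two such steps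

On these data alone, whether the low number of compound 2 belongs to ethyl alone remains open, as does how a longer chain such as propyl, or an amine, would read at this carbon. Also open, as far as these compounds go, is how methoxy at this carbon combines with methoxy on the other ring, and each reading here is the size of the effect at one dose, not a potency.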